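A few compounds are considered here, and "the series" means these few. Any claim that something is new, unique, unknown or untested is made for them only; others in the source may bear on it.

Measured compounds:
compound 1, `COc1ccc(-c2cc3cc(-c4ccccc4)cc(C(C)=O)c3[nH]2)cc1`, 32.8%;
compound 2, `COc1ccc(-c2cc3cc(-c4ccc(F)cc4)cc(C(C)=O)c3[nH]2)cc1`, 46.5%;
compound 3, `CC(=O)c1cc(/C=C/c2ccccc2)cc2cc(-c3ccccc3)[nH]c12`, 21.3%.

All three were tested in a functional assay on HeLa cells (Homo sapiens) for cytotoxicity, read by MTT assay, with a stated time of 2 days, tested at 100 uM; a higher number here means a weaker effect of the compound at the concentration tested, a lower number a stronger effect. Compound 3 gives the lowest of the three numbers, and its distance from compound 1 and from compound 2 is each time beyond the usual scatter. Compound 1 and compound 2 differ in one place only: fluoro in place of hydrogen on an aromatic carbon. This change made a step of a number 13.7 percentage points higher from compound 1 to compound 2 (beyond the scatter), a modest rise. The difference between the core of compound 3 and the core of compound 1 is not broken down here. Compound 4, `CC(=O)c1cc(/C=C/c2ccccc2)cc2cc(-c3ccc(F)cc3)[nH]c12`, has not been measured; it differs from compound 3 by fluoro in place of hydrogen on an aromatic carbon, the same change as that from compound 1 to compound 2, in the same place. For the measured compounds named here, a step of a number 11.7 percentage points higher from compound 3 to compound 4 (beyond the scatter) is therefore expected in this assay, resting on the single earlier step of a number 13.7 percentage points higher from compound 1 to compound 2 (beyond the scatter), with wider uncertainty because only one example is known. Compound 4 is estimated at 33%, between 20% and 48%.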

Compound 4, a percentage reported as activity, at one concentration (the size of the read-out at that concentration, not a potency): 24.3%
Estimate against measurement, compound 4: 8.7 percentage points above, and the stated range covers the measured number.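

In this assay, the change from phenyl to 4-fluorophenyl on the core of compound 3 gave a step of a number 3 percentage points higher from compound 3 to compound 4 (within the scatter), and the two known steps do not separate: the same change on two cores in this assay, a number 13.7 percentage points higher (beyond the scatter) from compound 1 to compound 2 and a number 3 percentage points higher (within the scatter) from compound 3 to compound 4, 10.7 percentage points apart, within the scatter of two such steps. The change can therefore be carried from the core of compound 1 to the core of compound 3 without a difference these data can resolve. For the compounds shown here, this does not show that the step has one fixed size, as only two pairs are known, one step beyond the scatter and the other within it.

The compounds shown leave open what a chloro group, an amine or a carboxylic acid would do in place of the fluoro. They also leave open whether the step would hold on any other core.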